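Nitro in Place of Iodo on the Chlorinated Analogue

The source may report more compounds than this note shows. Statements on the series, on what has been measured and on what is new or still open speak of the compounds shown alone.

Compound 1 `Nc1scc(-c2ccc(I)cc2)c1C(=O)c1ccccc1` is the reference point. In a functional assay on CHO cells for agonist activity at adenosine receptor A1 (Homo sapiens), read by fluorescence and ERK phosphorylation, with stated times of 30 min and 1.5 h, tested at 10 uM (on this read-out lower numbers stand for a weaker effect and higher numbers for a stronger effect at the one concentration tested), compound 1 gives 50%. Compound 2 `Nc1scc(-c2ccc([N+](=O)[O-])cc2)c1C(=O)c1ccccc1` differs from it by nitro in place of iodo on an aromatic carbon, and in this assay compound 2 gives 47%; the step is a number 3 percentage points lower from compound 1 to compound 2 (within the scatter). Compound 3 `Nc1scc(-c2ccc(I)cc2)c1C(=O)c1ccc(Cl)cc1` differs from compound 1 at the other ring, and in this assay compound 3 gives 61%; the step is a number 11 percentage points higher from compound 1 to compound 3 (beyond the scatter), leaving compound 3 the highest of the three, beyond the scatter from both compound 1 and compound 2.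

Compound 4 `Nc1scc(-c2ccc([N+](=O)[O-])cc2)c1C(=O)c1ccc(Cl)cc1` has not yet been measured. It stands to compound 3 as compound 2 stands to compound 1: the change is nitro in place of iodo on an aromatic carbon. The two cores differ by chloro in place of hydrogen on an aromatic carbon, and the place of the change reads the same in both pairs, so this is the same change made on a different core.

Since the step of a number 3 percentage points lower from compound 1 to compound 2 (within the scatter) stayed within the scatter, a step of about the same size is expected from compound 3 to compound 4, namely a number 3 percentage points lower from compound 3 to compound 4 (within the scatter). Compound 4 is therefore expected to give 58% in this assay, most likely between 45% and 70%. This rests on a single earlier instance of the change, so the range is kept wide.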

Compound 4, a percentage reported as activity, at one concentration (the size of the read-out at that concentration, not a potency): 52%
Estimate against measurement, compound 4: 6 percentage points above, and the stated range covers the measured number.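

Nitro in place of iodo on the chlorinated core gives a number 9 percentage points lower from compound 3 to compound 4 (within the scatter), and in this assay this step does not differ from the one seen on the core of compound 1: the same change on two cores in this assay, a number 3 percentage points lower (within the scatter) from compound 1 to compound 2 and a number 9 percentage points lower (within the scatter) from compound 3 to compound 4, 6 percentage points apart, within the scatter of two such steps. Chloro in place of hydrogen, read the other way round, gives a number 5 percentage points higher from compound 2 to compound 4 (within the scatter), and although only the earlier of its two steps lies beyond the scatter, the two cannot be told apart: the same change on two cores in this assay, a number 11 percentage points higher (beyond the scatter) from compound 1 to compound 3 and a number 5 percentage points higher (within the scatter) from compound 2 to compound 4, 6 percentage points apart, within the scatter of two such steps. Among the compounds shown here, this shows that in these four compounds each change carried from one core to the other without a detectable difference in its step, but it rests on only two cores and a single tested concentration, so it shows neither that the pair of changes would carry to further cores nor anything about potency.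

The compounds shown hold only iodo or nitro at the one place and only hydrogen or chloro at the other, so it stays open whether the same agreement would hold for an amine or a carboxylic acid in place of iodo, or for a methoxy or a fluoro in place of chloro. Also open, on these data alone, is whether the steps would keep their size at other concentrations in this assay.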